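Microsomal clearance notes: the step from compound 2 to compound 4

The source may hold more compounds than are shown below. What is called first, only, known or untested is meant among the compounds shown, and "the series" means these compounds.

Measured so far:
compound 1 `Cn1cc(-c2cnc(NCc3c(F)ccc4c3CCO4)c3cn[nH]c(=O)c23)cn1`, which in an ADME assay on microsomes from liver (Homo sapiens) for metabolic stability, read by LC-MS, using NADPH, with stated times of 5 min and 30 min, tested at 1 uM (a lower number here means slower removal, a higher number faster removal of the compound), gives 21 mL.min-1.g-1
compound 2 `O=C1CCCN1c1cnc(NCc2c(F)ccc3c2CCO3)n2cnnc12`, which in this assay gives < 3 mL.min-1.g-1, a limit of the assay
compound 3 `CNC(=O)c1ccc(-c2cnc(NCc3c(F)ccc4c3CCO4)c3cn[nH]c(=O)c23)c(C)n1`, which in this assay gives 23 mL.min-1.g-1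

Compound 2 sits at the floor of this assay: its reading is a limit and not a number (the limit of < 3 mL.min-1.g-1 in this assay, at which 1 of the 3 values shown sits). Among the measured compounds shown here, the one measured step, a 1.1-fold higher number from compound 1 to compound 3 (0.04 log units; within the scatter), lies on the core shared by compound 1 and compound 3, not on the core of compound 2, and it is within the scatter; it therefore says nothing direct about the exchange considered here. Compound 4 `Fc1ccc2c(c1CNc1ncc(Oc3ccccc3)c3nncn13)CCO2` is the next member. It differs from compound 2 by phenoxy in place of 2-oxopyrrolidin-1-yl on an aromatic carbon. For the measured compounds named here, no measured step in the set bears on this exchange, so the direction and size of the change in this assay cannot be read from the data, and the only anchor is that compound 2 reads as a limit. For compound 4 the intrinsic clearance is expected to be about 8 mL.min-1.g-1, in the range 3 mL.min-1.g-1 to 25 mL.min-1.g-1. The step this estimate implies, an at least 2.6-fold higher number from compound 2 to compound 4 (0.42 log units; beyond the scatter), is an expectation only and may again come back as a limit.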

Compound 4, intrinsic clearance in microsomes: 18 mL.min-1.g-1
Compound 4: middle estimate off by 2.3-fold (0.35 log units), on the low side; the measured number falls inside the stated range.
By their numbers in this assay, from the lowest: compounds 4, 1 and 3 (each within the scatter of the next). At a limit, below all of these: compound 2.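

Phenoxy in place of 2-oxopyrrolidin-1-yl on this aromatic carbon gives the first step that can be read on the core of compound 2 in this assay: an at least 6.0-fold higher number from compound 2 to compound 4 (0.77 log units; beyond the scatter). Among the compounds shown here, the group at this place therefore moves the reading beyond the scatter, whereas the one earlier step, on the core shared by compound 1 and compound 3, stayed within it. The size of the new step remains a lower bound, as compound 2 is a limit and not a number: the limit of < 3 mL.min-1.g-1 in this assay, at which 1 of the 4 values shown sits.

With a single exchange at this place, the data do not show whether the step follows the six-membered aromatic ring or the ether oxygen of phenoxy. Going by these compounds, whether an amine or a carboxylic acid here would read closer to phenoxy or to 2-oxopyrrolidin-1-yl also stays open.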